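A few compounds are considered here, and "the series" means these few. Any claim that something is new, unique, unknown or untested is made for them only; others in the source may bear on it.

Measured so far:
- compound 1 `CCOc1ccc(C(=O)/C=C/c2ccc(F)cc2)cc1`: 53 nM
- compound 2 `O=C(/C=C/c1ccc(F)cc1)c1ccc(-n2ccnc2)cc1`: > 10000 nM
- compound 3 `COc1ccc(C(=O)/C=C/c2ccc(ON=C(c3ccccc3)c3ccccc3)cc2)cc1`: < 100 nM

Going by the values given here, in an assay on isolated protein for inhibition of Amine oxidase [flavin-containing] B (Homo sapiens) (on this read-out lower numbers stand for stronger inhibition and higher numbers for weaker inhibition), compound 1 gives 53 nM, and this is the only actual number among the three results. For compound 2 the assay reports only a limit, > 10000 nM, as the limit of > 10000 nM in this assay, at which 1 of the 3 values shown sits, states. For compound 3 it likewise reports only a limit, < 100 nM, as the limit of < 100 nM in this assay, at which 1 of the 3 values shown sits, states. Among the compounds with values here, the single measured step is an at least 180-fold higher number from compound 1 to compound 2 (2.27 log units; beyond the scatter), a change on the ring that carries the ethoxy group.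

Compound 4 `CCOc1ccc(C(=O)/C=C/c2ccc([N+](=O)[O-])cc2)cc1` is not yet measured. It keeps everything of compound 1 and changes only the other ring: nitro in place of fluoro on an aromatic carbon. Within the data shown here, no measured step touches this position of the shared core; the step from compound 1 to compound 2 concerns the opposite ring, and compound 3 differs from compound 1 in two places at once, so it gives no single step to lean on. With nothing pointing either way, compound 4 is expected to stay close to compound 1, giving an estimated 80 nM (range 20 nM to 400 nM), a step of a 1.5-fold higher number from compound 1 to compound 4 (0.18 log units; within the scatter) that is expected to lie within the scatter.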

Compound 4, half-maximal inhibitory concentration: 210 nM
Beside the measured number, compound 4's estimate is 2.6-fold (0.42 log units) below it, and the stated range covers the measured number.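

In this assay, the position that holds the fluoro group now has its first measured step: a 4.0-fold higher number from compound 1 to compound 4 (0.60 log units; beyond the scatter). This position therefore responds to a change, and replacing a single fluorine with the three heavy atoms of nitro weakens inhibition by more than the usual scatter, though the step is much smaller than the one on the other ring, an at least 180-fold higher number from compound 1 to compound 2 (2.27 log units; beyond the scatter). Nothing measured here accounts for the size or the direction of the nitro step.

With only fluoro and nitro shown at this position, it remains open how an amine or a carboxylic acid there would read, and two groups are too few to show a trend. On these data alone, it also remains open whether the nitro change would give a similar step with 1H-imidazol-1-yl in place of ethoxy.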